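The source may report more compounds than this note shows. Statements on the series, on what has been measured and on what is new or still open speak of the compounds shown alone.

Measured so far in an assay for inhibition of Indoleamine 2,3-dioxygenase 1 (Homo sapiens), with a stated time of 1 h, tested at 10 uM; a lower number here means less inhibition, a higher number more inhibition at the concentration tested (going by the name of the read-out):
compound 1 `OCc1ccc(CNc2cc(Br)cc3[nH]ncc23)cc1`: 45%
compound 2 `Nc1ccc(CNc2cc(Br)cc3[nH]ncc23)cc1`: 3%
compound 3 `Nc1cccc(CNc2cc(Br)cc3[nH]ncc23)c1`: 31%

Compound 3 stands second highest of these three numbers: compound 1 is higher and compound 2 lower, both gaps beyond the scatter. Compound 4 `FC(F)(F)c1cccc(CNc2cc(Br)cc3[nH]ncc23)c1` is not yet measured. It differs from compound 3 in one place: trifluoromethyl in place of amino on an aromatic carbon. Within the data shown here, no measured step swaps an amino group for a trifluoromethyl group, so none bears on this change directly. Among the measured compounds shown here, the only single-point step measured, a number 42 percentage points lower from compound 1 to compound 2 (beyond the scatter), shows that exchanging one group on this ring can move this assay a long way, in either direction in principle. For compound 4 a moderate rise is expected, a number 9 percentage points higher from compound 3 to compound 4 (within the scatter), with wide uncertainty. The estimate for compound 4 is 40%, spanning 15% to 65%.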

Compound 4, a percentage reported as inhibition, at one concentration (the size of the read-out at that concentration, not a potency): 16%
Compound 4: the middle estimate sits 24 percentage points above what was measured, and the stated range covers the measured number.
By their numbers in this assay, from the lowest: compound 2; then compound 4; then compound 3; then compound 1.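

In this assay the swap gives a number 15 percentage points lower from compound 3 to compound 4 (beyond the scatter) at this aromatic carbon, meta to a large group, so this place responds to the group it carries. Amino has 1 hydrogen-bond donor and 1 hydrogen-bond acceptor, trifluoromethyl has 0 of each and more heavy atoms, and here the amino compound keeps the higher number. No measurement on hand explains the drop. Among these compounds, open is how a hydroxymethyl, a methyl, a nitrile or a carboxylic acid on this same carbon would compare, and with only two groups tested here, no trend can be drawn.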